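A few compounds are considered here, and "the series" means these few. Any claim that something is new, unique, unknown or untested is made for them only; others in the source may bear on it.

In a functional assay on MCF7 cells (Homo sapiens) for cytotoxicity, read by MTT assay, with a stated time of 24 h (a higher number here means a weaker inhibitor, a lower number a stronger inhibitor), compound 1 `CCNc1cc(-c2ccc(NC(=O)Nc3ccc(C(F)(F)F)cc3)cc2C(F)(F)F)ccn1` gives 2390 nM, while compound 2 `O=C(Nc1cccc(Cl)c1)Nc1ccc(-c2ccnc(NCC3CC3)c2)c(C(F)(F)F)c1` gives 17400 nM. Compound 2 therefore holds the higher of the two numbers, and the gap between them lies beyond the usual scatter. Compound 3 `O=C(Nc1ccc(C(F)(F)F)cc1)Nc1ccc(-c2ccnc(NCC3CC3)c2)c(C(F)(F)F)c1` is derived from compound 2 by a single change, with 4-(trifluoromethyl)phenyl in place of 3-chlorophenyl on an amide-type nitrogen. Going by the values given here, no pair of measured compounds isolates this change, so any forecast is indirect. The expectation rests on compound 1, which carries the same 4-(trifluoromethyl)phenyl and gives 2390 nM. In this assay, a move to a lower number, beyond the scatter, is therefore expected, and the estimated step is a 3.9-fold lower number from compound 2 to compound 3 (0.59 log units; beyond the scatter). The estimate for compound 3 is 4500 nM, with an expected range of 1500 nM to 13000 nM.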

Compound 3, half-maximal inhibitory concentration: 15600 nM
The estimate for compound 3 lay 3.5-fold (0.54 log units) below the measured number; the whole stated range lies below it.
By their numbers in this assay, from the lowest: compound 1; then compounds 3 and 2 (each within the scatter of the next).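

In this assay, 4-(trifluoromethyl)phenyl in place of 3-chlorophenyl on the amide-type nitrogen, with the cyclopropyl kept, gives a 1.1-fold lower number from compound 2 to compound 3 (0.05 log units; within the scatter) and so leaves the number unmoved at this position. The gap seen earlier can now be tied to one place: with 4-(trifluoromethyl)phenyl held constant, cyclopropyl in place of methyl on the saturated chain carbon bound to a nitrogen on an aromatic ring gives a 6.5-fold higher number from compound 1 to compound 3 (0.81 log units; beyond the scatter) in the same assay. Nothing available explains either step.

On these data alone, it remains open whether 3-chlorophenyl and 4-(trifluoromethyl)phenyl would also read alike with the smaller ethyl group on that nitrogen. As far as these compounds go, how a 4-methoxyphenyl on the amide-type nitrogen, or a hydroxyethyl or longer chain on the nitrogen on the aromatic ring, would read also stays unknown.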